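Carbamate in place of aryl urea on the carbonyl

The source may hold more compounds than are shown below. What is called first, only, known or untested is meant among the compounds shown, and "the series" means these compounds.

Compound 3 `O=C(Nc1ccc(Cl)cc1)Nc1c(C(O)(C(F)(F)F)C(F)(F)F)ccc2ccccc12` is the lowest of the two numbers shown in an assay on LtK cells with ATP-sensitive inward rectifier potassium channel 11 (Homo sapiens) as the target; on this read-out lower numbers stand for an effect already at smaller amounts and higher numbers for an effect only at larger amounts of compound: compound 3 gives 276 nM. Its nearest neighbour is compound 1 `CC(C)C(=O)Nc1c(C(O)(C(F)(F)F)C(F)(F)F)ccc2ccccc12`, which in this assay gives 6630 nM; the step is a 24-fold lower number from compound 1 to compound 3 (1.38 log units; beyond the scatter). Compound 2 `CCCC(C)C(=O)Nc1c(C(O)(C(F)(F)F)C(F)(F)F)ccc2ccccc12` in this assay reaches only a limit, > 10000 nM (the limit of > 10000 nM in this assay, at which 1 of the 3 values shown sits). Compared with compound 1 the step is an at least 1.5-fold higher number from compound 1 to compound 2 (0.17 log units; that floor lies within the scatter), and against compound 3 it is an at least 36-fold lower number from compound 2 to compound 3 (1.55 log units; beyond the scatter).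

Compound 4 `CC(C)OC(=O)Nc1c(C(O)(C(F)(F)F)C(F)(F)F)ccc2ccccc12` differs from compound 3 in one place: isopropoxy in place of (4-chlorophenyl)amino on a carbonyl carbon. The two measured steps that bear on it both run the other way, from a small alkyl on the carbonyl carbon to the (4-chlorophenyl)amino and both are large, so the reverse, toward a small isopropoxy group, is expected to undo most of that gain. Compound 4 thus sits closer to compound 1 than to compound 3, and the step is estimated as a 14-fold higher number from compound 3 to compound 4 (1.16 log units; beyond the scatter). In this assay compound 4 is expected to give about 4000 nM, most likely between 1200 nM and 12000 nM, with a real chance that the assay returns only its limit.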

Compound 4, half-maximal effective concentration: 1160 nM
The estimate for compound 4 lay 3.4-fold (0.54 log units) above the measured number; measured number below the stated range.
By their numbers in this assay, from the lowest: compound 3; then compound 4; then compound 1. At a limit, above all of these: compound 2.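

Working from this assay, the carbonyl position now shows a change of its linking atom alone: the step of a 5.7-fold lower number from compound 1 to compound 4 (0.76 log units; beyond the scatter) is read with isopropoxy in place of isopropyl, so an oxygen-linked small group and a carbon-linked one of similar shape are not equivalent here. The aryl urea is also not the only route to a lower number, since the step of a 4.2-fold higher number from compound 3 to compound 4 (0.62 log units; beyond the scatter) is modest. The step of a 24-fold lower number from compound 1 to compound 3 (1.38 log units; beyond the scatter) is large, and compound 3 remains the lowest of the measured numbers. Compound 2 has only a limit, so the step of an at least 8.6-fold lower number from compound 2 to compound 4 (0.93 log units; beyond the scatter) gives a minimum size and not a measured one, which is all that this comparison supports: the limit of > 10000 nM in this assay, at which 1 of the 4 values shown sits.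

The shown compounds do not separate the contribution of the (4-chlorophenyl) ring from that of the urea nitrogen, and a 4-chlorophenoxy or an isopropylamino group on the same carbonyl carbon would divide that remaining gap. How far the carbamate tolerates other groups, such as methoxy, tert-butoxy or benzyloxy, also stays open, and nothing here gives a cause for any of these steps.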